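Swapping a Fluorophenoxy Group for Phenyl in a Tetrazole Series

The compounds below may be only part of what the source reports. "The series", "measured", "known", "first", "only" and "open" are said of these compounds alone.

Two compounds in this series have been examined in an ADME assay on S9 fraction from liver (Rattus norvegicus) for metabolic stability, read by LC-MS, using NADPH, with a stated time of 30 min; on this read-out lower numbers stand for a less stable compound and higher numbers for a more stable compound. Compound 1 `CC(Oc1ccc(-c2ccccc2)cc1)C(=O)Cn1nnc(-c2ccc(Cl)cc2)n1` gives 18%, and compound 2 `CC(Oc1ccc(Oc2ccc(F)cc2)cc1)C(=O)Cn1nnc(-c2ccc(C(=O)O)cc2)n1` gives 33%. Of the two numbers, compound 2 stands highest, and its gap to compound 1 lies beyond the usual scatter of such measurements. Compound 3 `CC(Oc1ccc(-c2ccccc2)cc1)C(=O)Cn1nnc(-c2ccc(C(=O)O)cc2)n1` has not yet been measured in this assay. It differs from compound 2 by a single change: phenyl in place of 4-fluorophenoxy on an aromatic carbon. Among the measured compounds shown here, no pair of measured compounds differs in only this one place, so the size of this step has to be guessed. For the measured compounds named here, compound 3 shares its biphenyl part with compound 1, whose 18% is the lower of the two known numbers, so a modest drop is expected; the step from compound 2 to compound 3 is estimated at a number 8 percentage points lower from compound 2 to compound 3 (within the scatter), close to the scatter. The expected value for compound 3 is 25%, with a likely range from 10% to 42%.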

Compound 3, percent of the compound remaining: 30%
The estimate for compound 3 lay 5 percentage points below the measured number; low and high end bracket the measured number.
By their numbers in this assay, from the lowest: compound 1; then compounds 3 and 2 (each within the scatter of the next).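

In this assay, phenyl in place of 4-fluorophenoxy gives a number 3 percentage points lower from compound 2 to compound 3 (within the scatter), so with carboxy present elsewhere in the molecule, this site para to a large group tolerates the exchange without a change that can be told from the scatter. Carboxy in place of chloro on an aromatic carbon gives a number 12 percentage points higher from compound 1 to compound 3 (beyond the scatter), the first single change in this set to reach beyond the scatter, although the size of the step is modest. Nothing available explains either step.

From the compounds shown here alone, it remains open whether the exchange of phenyl and 4-fluorophenoxy would be just as small with chloro in place of carboxy. Going by these compounds, it is also open how an amide, an amine or a methyl group would compare with carboxy or phenyl at these two sites.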